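Trimethoxyphenyl Ketone Variant of a Weak Cytotoxic Series

The source may hold more compounds than are shown below. What is called first, only, known or untested is meant among the compounds shown, and "the series" means these compounds.

Compound 1 `COc1cc(-c2nnc3n2NC(c2cccs2)C(C(=O)c2ccc(F)cc2)S3)cc(OC)c1OC` gives 54200 nM in a functional assay on HepG2 cells (Homo sapiens) for cytotoxicity, read by MTT assay, with a stated time of 48 h; a higher number here means a weaker inhibitor, a lower number a stronger inhibitor.
Compound 3 `COc1cc(-c2nnc3n2NC(c2ccco2)C(C(=O)c2ccccc2)S3)cc(OC)c1OC` gives 90900 nM in this assay.
Compound 2 `COc1cc(-c2nnc3n2NC(c2ccco2)C(C(=O)c2ccc(C(F)(F)F)cc2)S3)cc(OC)c1OC` reaches only the limit of > 100000 nM in this assay, so no number is known for it.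

Among the two numbers available, compound 1 has the lowest; its nearest neighbour is compound 3, whose number sits higher by a gap that is within the scatter. Among the compounds with values here, the only measured step in this set runs an at least 1.1-fold lower number from compound 2 to compound 3 (0.04 log units; that floor lies within the scatter), a change that did not move the number beyond the scatter, and it touches a ring on the carbonyl, not the ring that changes here. Compound 4 `COc1cc(C(=O)C2Sc3nnc(-c4cc(OC)c(OC)c(OC)c4)n3NC2c2cccs2)cc(OC)c1OC` differs from compound 1 by 3,4,5-trimethoxyphenyl in place of 4-fluorophenyl on a carbonyl carbon. Within the data shown here, no measured step bears on this exchange, so there is nothing from which to expect a shift in one direction; the three measured compounds cluster at weak inhibition, with one at the limit (the limit of > 100000 nM in this assay, at which 1 of the 3 values shown sits). Compound 4 is therefore expected to stay near compound 1, with a step of a 1.1-fold higher number from compound 1 to compound 4 (0.04 log units; within the scatter) that lies within the scatter. The estimate for compound 4 is 60000 nM, with a range from 20000 nM to 200000 nM.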

Compound 4, half-maximal inhibitory concentration: > 100000 nM
Compound 4 gave a limit, no number; the forecaster's own chance of this, stated with the estimate: 30%; middle value at least 1.6-fold (0.22 log units) from the limit.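

At the carbonyl carbon, whose other neighbour is a saturated ring carbon, 3,4,5-trimethoxyphenyl in place of 4-fluorophenyl gives an at least 1.8-fold higher number from compound 1 to compound 4 (0.26 log units; that floor lies within the scatter), read in this assay. Compound 4 stands at a limit and has no number, so only a floor of this step is known, and that floor does not establish a shift beyond the scatter. The earlier compounds had shown only the exchange of trifluoromethyl for hydrogen on a ring at the carbonyl, and this result adds that the larger 3,4,5-trimethoxyphenyl brings no sign of stronger inhibition, although the size of the step stays unreadable because the series is pressed against the top of the range: the limit of > 100000 nM in this assay, at which 2 of the 4 values shown sit.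

Going by these compounds, whether an amine or a carboxylic acid on this ring, or a single methoxy in place of the three, would bring the number down remains open. Also open, on these data alone, is what 4-fluorophenyl does compared with an unsubstituted phenyl on the core of compound 1, since compound 1 and compound 3 differ in more than one place.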